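The source may report more compounds than this note shows. Statements on the series, on what has been measured and on what is new or still open speak of the compounds shown alone.

Measured compounds:
- Compound 1, `CC(=O)Nc1ccc2oc(-c3ccccc3F)c(O)c(=O)c2c1`: 171000 nM
- Compound 2, `CC(=O)Nc1ccc2oc(-c3cccc(F)c3)c(O)c(=O)c2c1`: 26500 nM
- Compound 3, `COc1c(-c2ccccc2F)oc2ccc(NC(C)=O)cc2c1=O`: 180000 nM

These three compounds were tested in an ADME assay on MT4 cells (Homo sapiens) for cytotoxicity, read by MTT assay, with a stated time of 4 days; on this read-out lower numbers stand for higher toxicity in this test and higher numbers for lower toxicity in this test. Compound 1 carries a 2-fluorophenyl group on its core; compound 2 carries a 3-fluorophenyl group instead, (3-fluorophenyl in place of 2-fluorophenyl on an aromatic carbon), and in this assay this gave a 6.5-fold lower number from compound 1 to compound 2 (0.81 log units; beyond the scatter). Compound 3 differs from compound 1 in the core itself, (methyl in place of hydrogen on an oxygen on an aromatic ring), and in this assay the numbers of compound 1 and compound 3 lie within the usual scatter of each other: a 1.1-fold higher number from compound 1 to compound 3 (0.02 log units; within the scatter).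

Compound 4, `COc1c(-c2cccc(F)c2)oc2ccc(NC(C)=O)cc2c1=O`, has not yet been measured. It relates to compound 3 as compound 2 relates to compound 1: 3-fluorophenyl in place of 2-fluorophenyl on an aromatic carbon. The surroundings are not identical, since in compound 1 the changed group sits ortho to a hydroxy group (1 heavy atom), whereas in compound 3 it sits ortho to a methoxy group (2 heavy atoms), so this is the same kind of change rather than the same change. Within the data shown here, still, because the only comparable step, a 6.5-fold lower number from compound 1 to compound 2 (0.81 log units; beyond the scatter), lay beyond the scatter, a step of similar size is expected here, a 6.4-fold lower number from compound 3 to compound 4 (0.81 log units; beyond the scatter). On that basis compound 4 is estimated at 28000 nM in this assay, most likely between 12000 nM and 70000 nM.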

Compound 4, half-maximal cytotoxic concentration: 210000 nM
The estimate for compound 4 lay 7.5-fold (0.88 log units) below the measured number; measured number above the stated range.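

In this assay, 3-fluorophenyl in place of 2-fluorophenyl on the core of compound 3 gave a 1.2-fold higher number from compound 3 to compound 4 (0.07 log units; within the scatter), so the clear step seen on the core of compound 1 did not carry over: the same change on two cores in this assay, a 6.5-fold lower number (0.81 log units; beyond the scatter) from compound 1 to compound 2 and a 1.2-fold higher number (0.07 log units; within the scatter) from compound 3 to compound 4, 7.5-fold (0.88 log units) apart, beyond the scatter of two such steps

Read the other way, methyl in place of hydrogen on the oxygen gave a 7.9-fold higher number from compound 2 to compound 4 (0.90 log units; beyond the scatter), although the same change made no difference beyond the scatter when the 2-fluorophenyl group was present: the same change on two cores in this assay, a 1.1-fold higher number (0.02 log units; within the scatter) from compound 1 to compound 3 and a 7.9-fold higher number (0.90 log units; beyond the scatter) from compound 2 to compound 4, 7.5-fold (0.88 log units) apart, beyond the scatter of two such steps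

Within these four compounds, then, the result of each change depends on the other, so neither step can simply be transferred to a new compound; the data do not show why this happens, and four compounds in a single assay cannot show whether it holds elsewhere in the series.

The compounds shown leave open whether an ethyl group on that oxygen would behave as the methyl group does alongside 3-fluorophenyl. They also leave open whether chlorine in place of the fluorine would give the same dependence between the two positions of the ring substituent and the group on the oxygen.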